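The compounds below may be only part of what the source reports. "The series", "measured", "known", "first", "only" and "open" are said of these compounds alone.

Measured in a functional assay on MDA-MB-468 cells (Homo sapiens) for antiproliferative activity, read by sulforhodamine B assay, with a stated time of 4 days; a lower number here means a stronger inhibitor of growth, a higher number a weaker inhibitor of growth:
- compound 1 `COc1cc(Cl)c(-c2nc(SCC(=O)NC(C)(C)C)nc3[nH]cc(C#N)c23)cc1OC`: 84 nM
- compound 2 `COc1cc(Cl)c(-c2nc(SCC(=O)NC(C)C)nc3[nH]cc(C#N)c23)cc1OC`: 102 nM
- compound 3 `COc1cc(Cl)c(-c2nc(SCC(=O)N3CCC3)nc3[nH]cc(C#N)c23)cc1O`: 28 nM

Compound 3 gives the lowest number of the three, with compound 1 and compound 2 both beyond the scatter from it. Compound 4 `COc1cc(Cl)c(-c2nc(SCC(=O)N3CCC3)nc3[nH]cc(C#N)c23)cc1OC`, not yet measured, differs from compound 3 by methyl in place of hydrogen on an oxygen on an aromatic ring, hydroxy to methoxy.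

Going by the values given here, the one measured step, a 1.2-fold higher number from compound 1 to compound 2 (0.08 log units; within the scatter), lies at a different place and does not test this change. Compound 1 at 84 nM and compound 2 at 102 nM carry the methoxy, but their amide groups also differ from that of compound 3, so they offer only indirect support. Among the compounds with values here, a modest rise in this assay is expected, though no measured pair isolates it.

The expected move is a 2.1-fold higher number from compound 3 to compound 4 (0.33 log units; beyond the scatter). The estimate for compound 4 is 60 nM, with an expected range of 22 nM to 160 nM.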

Compound 4, concentration for 50% growth inhibition: 35 nM
The estimate for compound 4 lay 1.7-fold (0.23 log units) above the measured number; low and high end bracket the measured number.
By their numbers in this assay, from the lowest: compounds 3 and 4 (each within the scatter of the next); then compounds 1 and 2 (each within the scatter of the next).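

In this assay the change from hydroxy to methoxy on an oxygen on an aromatic ring gives a 1.3-fold higher number from compound 3 to compound 4 (0.10 log units; within the scatter), so with the azetidin-1-yl amide this position accepts either group. With the methoxy held constant, azetidin-1-yl on the carbonyl carbon gives a 2.9-fold lower number from compound 2 to compound 4 (0.46 log units; beyond the scatter) in place of isopropylamino and a 2.4-fold lower number from compound 1 to compound 4 (0.38 log units; beyond the scatter) in place of (tert-butyl)amino , so among these compounds the larger gaps follow the amide group and not this oxygen. No measurement at hand gives a cause for these steps.

Open, from the compounds shown here alone, is whether a longer chain on this oxygen, or one ending in an amine or a carboxylic acid, would keep the number in this range. Also open, going by these compounds, is whether hydroxy and methoxy stay equivalent with the isopropylamino and (tert-butyl)amino amides.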